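Methyl step on the pyrazolyl ring and MCF7 cytotoxicity

The compounds below may be only part of what the source reports. "The series", "measured", "known", "first", "only" and "open" are said of these compounds alone.

Three compounds are measured. In a functional assay on MCF7 cells (Homo sapiens) for cytotoxicity, read by MTT assay, with a stated time of 72 h (on this read-out higher numbers stand for weaker inhibition and lower numbers for stronger inhibition), compound 2 `Cc1cc(S(=O)(=O)/N=C(\N)n2nccc2-c2ccccc2)c(SCc2cccc(C(F)(F)F)c2)cc1Cl` gives 17000 nM. Compound 1 `Cc1cc(-c2ccccc2)n(/C(N)=N/S(=O)(=O)c2cc(C)c(Cl)cc2SCc2cccc(C(F)(F)F)c2)n1` carries one change relative to compound 2, (methyl in place of hydrogen on an aromatic carbon), and in this assay compound 1 gives 41000 nM, a step of a 2.4-fold higher number from compound 2 to compound 1 (0.38 log units; beyond the scatter). Compound 3 `Cc1cc(S(=O)(=O)/N=C(\N)n2nccc2-c2ccccc2)c(SCc2ccccc2C(F)(F)F)cc1Cl` differs from compound 2 in the core by 2-(trifluoromethyl)phenyl in place of 3-(trifluoromethyl)phenyl on a saturated chain carbon bound to a sulfur; in this assay compound 3 gives 21000 nM, a step of a 1.2-fold higher number from compound 2 to compound 3 (0.09 log units; within the scatter).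

Compound 4 `Cc1cc(-c2ccccc2)n(/C(N)=N/S(=O)(=O)c2cc(C)c(Cl)cc2SCc2ccccc2C(F)(F)F)n1` is not yet measured and differs from compound 3 by methyl in place of hydrogen on an aromatic carbon. The place of this change is word for word the same as for compound 1, so it is the same change made on the core of compound 3. Among the compounds with values here, only one earlier instance exists, so the expectation rests on a single step. The step from compound 3 to compound 4 is expected to be about a 2.4-fold higher number from compound 3 to compound 4 (0.38 log units; beyond the scatter) because a 2.4-fold higher number from compound 2 to compound 1 (0.38 log units; beyond the scatter) was seen for the same change. Compound 4 is therefore expected near 50000 nM, between 25000 nM and 100000 nM.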

Compound 4, half-maximal inhibitory concentration: 101000 nM
The estimate for compound 4 lay 2.0-fold (0.31 log units) below the measured number, outside the stated range (above it).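

In this assay, methyl in place of hydrogen on the aromatic carbon again gives a higher number on the core of compound 3, with a 4.8-fold higher number from compound 3 to compound 4 (0.68 log units; beyond the scatter) and a gap to the earlier step that stays within the scatter: the same change on two cores in this assay, a 2.4-fold higher number (0.38 log units; beyond the scatter) from compound 2 to compound 1 and a 4.8-fold higher number (0.68 log units; beyond the scatter) from compound 3 to compound 4, 2.0-fold (0.30 log units) apart, within the scatter of two such steps.

2-(trifluoromethyl)phenyl in place of 3-(trifluoromethyl)phenyl gives a 2.5-fold higher number from compound 1 to compound 4 (0.39 log units; beyond the scatter) on the methyl-bearing core, and this step too does not differ from its earlier counterpart beyond the scatter: the same change on two cores in this assay, a 1.2-fold higher number (0.09 log units; within the scatter) from compound 2 to compound 3 and a 2.5-fold higher number (0.39 log units; beyond the scatter) from compound 1 to compound 4, 2.0-fold (0.30 log units) apart, within the scatter of two such steps.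

These two pairs show the methyl step going the same way on both cores, but they do not fix its size on any further core or show why it occurs.

Open, on these data alone, is whether an ethyl group or an amine in place of that methyl would give a similar step. Also open, as far as these compounds go, is whether the step holds with a pyridyl group in place of the phenyl.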